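The source may hold more compounds than are shown below. What is called first, only, known or untested is meant among the compounds shown, and "the series" means these compounds.

Three related compounds have been tested so far in a functional assay on Molt4/C8 cells (Homo sapiens) for inhibition; on this read-out higher numbers stand for weaker inhibition and lower numbers for stronger inhibition. Compound 1 `O=C1/C(=C/c2ccc(Cl)cc2Cl)CCCc2ccccc21` did not give a number, only a limit of the assay: > 500000 nM. Compound 2 `O=C1/C(=C/c2ccccc2Br)CCCc2ccccc21` gives a true number, 38400 nM. Compound 3 `O=C1/C(=C/c2ccccc2Br)CCc2ccccc21` also gives a true number, 36800 nM. These two values lie within the usual scatter of repeated measurements, so compound 2 and compound 3 cannot be told apart in this assay. Among the measured compounds shown here, they are the only two compounds with a measured number so far.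

The next compound to be tested is compound 4 `O=C1/C(=C/c2ccccc2Cl)CCCc2ccccc21`, which is compound 2 with one small change: chloro in place of bromo on an aromatic carbon, ortho to a large group (chloro in place of bromo on an aromatic carbon). For the measured compounds named here, no swap of this kind has yet been measured within this small set, so there is no direct precedent to draw on. The best starting point is compound 2 itself, at 38400 nM, and no change beyond the scatter is expected in either direction. The expected step is a 1.0-fold higher number from compound 2 to compound 4 (0.02 log units; within the scatter). The range is kept wide because so few numbers are available. For compound 4 the estimated value is 40000 nM, with an expected range of 13000 nM to 120000 nM.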

Compound 4, half-maximal inhibitory concentration in the Molt4/C8 assay: 37100 nM
Compound 4: the middle estimate sits 1.1-fold (0.03 log units) above what was measured; low and high end bracket the measured number.
By their numbers in the Molt4/C8 assay, from the lowest: compounds 3, 4 and 2 (each within the scatter of the next). At a limit, above all of these: compound 1.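

In the Molt4/C8 assay, chloro in place of bromo on an aromatic carbon, ortho to a large group, gives a 1.0-fold lower number from compound 2 to compound 4 (0.01 log units; within the scatter). In the Molt4/C8 assay compound 2 gives 38400 nM and compound 4 gives 37100 nM, so at this position the two groups cannot be told apart on this read-out. In a physicochemical assay for lipophilicity (a higher number here means a more lipophilic compound, a lower number a more polar compound), compound 2 gives 5.04 and compound 4 gives 5.04. In the physicochemical assay, the same swap gives no change at the digits printed from compound 2 to compound 4 (within the scatter), which means that neither read-out separates the pair. Compound 4 also provides the first comparison with compound 1, and in the Molt4/C8 assay hydrogen in place of chloro on an aromatic carbon gives an at least 13-fold lower number from compound 1 to compound 4 (1.12 log units; beyond the scatter), a large step whose true size stays unknown since one end of it is a limit of the assay and not a number: the limit of > 500000 nM in the Molt4/C8 assay, at which 1 of the 4 values shown sits.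

The compounds shown leave open whether a group of a different kind at the ortho position, such as a methoxy group or an amine, would move the number in the Molt4/C8 assay beyond the scatter, since only chloro and bromo can be compared there. They also leave open whether a smaller group such as fluoro, in place of the extra chloro of compound 1, would bring the same loss of inhibition.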